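Amide swap on the stilbene core: from isopropyl to phenylpiperidine

The source may report more compounds than this note shows. Statements on the series, on what has been measured and on what is new or still open speak of the compounds shown alone.

Of the compounds shown here, two sharing one core have been measured so far. Compound 1 `CCCCN(CCCC)C(=O)/C=C/c1c(/C=C/c2ccc(OC)cc2)cc(OC)cc1OC` carries a dibutylamino group on its carbonyl carbon, and in a functional assay on A549 cells (Homo sapiens) for inhibition, read by MTT assay, with a stated time of 48 h (a lower number here means a stronger inhibitor, a higher number a weaker inhibitor), compound 1 gives 6160 nM. Compound 2 `COc1ccc(/C=C/c2cc(OC)cc(OC)c2/C=C/C(=O)NC(C)C)cc1` carries an isopropylamino group in that place, and in this assay compound 2 gives 2360 nM. That change produced a 2.6-fold lower number from compound 1 to compound 2 (0.42 log units; beyond the scatter), so compound 2 holds the lower of the two numbers, and the gap to compound 1 is beyond the scatter.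

The next compound, compound 3 `COc1ccc(/C=C/c2cc(OC)cc(OC)c2/C=C/C(=O)N2CCC(c3ccccc3)CC2)cc1`, changes the same position again: 4-phenylpiperidin-1-yl in place of isopropylamino on a carbonyl carbon. Going by the values given here, only one measured step bears on this, the step from compound 1 to compound 2, where a larger tertiary amide gave the higher number. Compound 3 returns to a tertiary amide of even greater size, so a rise in this assay is expected, of roughly the size seen before, though a single step is thin ground. The step is estimated as a 2.3-fold higher number from compound 2 to compound 3 (0.37 log units; beyond the scatter). For compound 3 the expected value is 5500 nM, with a likely range from 1800 nM to 17000 nM.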

Compound 3, half-maximal inhibitory concentration: 6690 nM
Beside the measured number, compound 3's estimate is 1.2-fold (0.09 log units) below it; the measured number falls inside the stated range.
By their numbers in this assay, from the lowest: compound 2; then compounds 1 and 3 (each within the scatter of the next).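

In this assay, the move to 4-phenylpiperidin-1-yl on the carbonyl carbon gave a 2.8-fold higher number from compound 2 to compound 3 (0.45 log units; beyond the scatter), so this second change away from isopropylamino also leaves compound 2 with the lowest number of the three. The two groups without the amide hydrogen, one an open pair of butyl chains and the other carrying two rings, could not be told apart, with a 1.1-fold higher number from compound 1 to compound 3 (0.04 log units; within the scatter). No measurement here explains why the number differs between these amides.

Compound 2 is the only one of the three with the amide hydrogen, and it also carries the smallest of the three groups, so these compounds cannot show which of the two features goes with its lower number. Octylamino, a longer chain that keeps the amide hydrogen, and dimethylamino, a small group without it, would pull these features apart, but how either would read in this assay remains open.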